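This account rests on a few compounds, and the source may have more. Where it says the series, first, only, none or still open, it means among the compounds named here.

Compound 1 `COc1cc2c(Nc3ccc4sc(C(=O)Nc5c(C)cccc5Cl)cc4c3)ncnc2cc1OCCCN1CCCCC1C` gives 3450 nM in a functional assay on U-937 cells (Homo sapiens) for cytotoxicity, read by MTT assay and WST assay, with a stated time of 72 h (on this read-out higher numbers stand for weaker inhibition and lower numbers for stronger inhibition), the lowest of the three numbers recorded; compound 3 `Cc1nc(Nc2ccc3sc(C(=O)Nc4c(C)cccc4Cl)cc3c2)cc(N2CCN(C)CC2)n1` gives 15000 nM and compound 2 `Cc1nc(Nc2ccc3sc(C(=O)Nc4c(C)cccc4Cl)cc3c2)cc(N2CCC(C)CC2)n1` gives 20600 nM, both beyond the scatter above it. Compound 4 `COc1cc2c(Nc3ccc4sc(C(=O)Nc5c(C)cccc5Cl)cc4c3)ncnc2cc1OCCCN1CCN(C)CC1` differs from compound 1 by 4-methylpiperazin-1-yl in place of 2-methylpiperidin-1-yl on a saturated chain carbon, three bonds along the chain from an oxygen on an aromatic ring. For the measured compounds named here, the only measured step that bears on this is a 1.4-fold lower number from compound 2 to compound 3 (0.14 log units; within the scatter), an exchange of a saturated ring amine for a 4-methylpiperazin-1-yl group, though on a different core and on an aromatic carbon rather than a saturated chain carbon. That step stayed within the scatter, so for compound 4 an expected step of a 1.2-fold lower number from compound 1 to compound 4 (0.06 log units; within the scatter) is estimated, with no shift beyond the scatter. Compound 4 is therefore expected to give about 3000 nM, between 1200 nM and 8000 nM.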

Compound 4, half-maximal inhibitory concentration: 3480 nM
For compound 4 the middle estimate is 1.2-fold (0.06 log units) below the measured one; measured number inside the range.
By their numbers in this assay, from the lowest: compounds 1 and 4 (each within the scatter of the next); then compounds 3 and 2 (each within the scatter of the next).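

On a saturated chain carbon, three bonds along the chain from an oxygen on an aromatic ring, this assay registers a 1.0-fold higher number from compound 1 to compound 4 (0.00 log units; within the scatter). For the compounds shown here, the earlier within-scatter exchange had been seen only on an aromatic carbon of a different core, so this result extends that reading to the chain of the shared core, where the methyl also moves from the 2-position of a piperidine to the 4-position of a piperazine. No available evidence explains this outcome.

The compounds shown leave open whether morpholin-4-yl or an open-chain dimethylamino group would give a similar number here. They also leave open whether a longer chain would change it.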